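Aryl ether substituents on the shared core

The source may hold more compounds than are shown below. What is called first, only, known or untested is meant among the compounds shown, and "the series" means these compounds.

Measured compounds:
compound 1 `Cc1ccccc1Oc1ccc(N2C[C@@H](C(F)(F)F)C[C@H]2CC(=O)O)cc1` — 73 nM
compound 2 `O=C(O)C[C@@H]1C[C@H](C(F)(F)F)CN1c1ccc(Oc2ccccc2C(F)(F)F)cc1` — 310 nM
compound 3 `O=C(O)C[C@@H]1C[C@H](C(F)(F)F)CN1c1ccc(Oc2ccccc2OC(F)(F)F)cc1` — 170 nM

In a functional assay on cells for agonist activity at Free fatty acid receptor 1 (Homo sapiens), read by FLIPR and calcium flux, with a stated time of 100 s (a higher number here means that more compound is needed for the effect, a lower number that less compound is needed), compound 1 gives the lowest of the three numbers; the nearest is compound 3 and the furthest is compound 2. Both measured steps leaving compound 1 alter the methyl group itself: a 4.2-fold higher number from compound 1 to compound 2 (0.63 log units; beyond the scatter) and a 2.3-fold higher number from compound 1 to compound 3 (0.37 log units; beyond the scatter). Between the two fluorinated analogues the gap is small, a 1.8-fold lower number from compound 2 to compound 3 (0.26 log units; within the scatter).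

Compound 4 `Cc1cc(OCc2ccccc2)ccc1Oc1ccc(N2C[C@@H](C(F)(F)F)C[C@H]2CC(=O)O)cc1` keeps the methyl group of compound 1 and differs from it by benzyloxy in place of hydrogen on an aromatic carbon, a benzyloxy in place of hydrogen on an aromatic carbon, meta to a methyl group and para to a large group. Among the measured compounds shown here, no measured step touches this position, so there is no direct precedent. The steps from compound 1 do show that alterations on this ring have so far moved the number modestly and only upward, which sets the expectation. The step is therefore expected to be small, in the direction of a higher number if any, a 1.6-fold higher number from compound 1 to compound 4 (0.22 log units; within the scatter). Compound 4 is estimated at 120 nM, with a range of 30 nM to 500 nM.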

Compound 4, half-maximal effective concentration: 120 nM
For compound 4 middle estimate and measured number coincide at the digits printed; measured number inside the range.
By their numbers in this assay, from the lowest: compounds 1, 4, 3 and 2 (each within the scatter of the next, the first and the last beyond it).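

In this assay, among the compounds shown here, this is the first change at this position, an aromatic carbon meta to a methyl group and para to a large group, and it leaves the methyl group of compound 1 in place: benzyloxy in place of hydrogen gives a 1.6-fold higher number from compound 1 to compound 4 (0.22 log units; within the scatter) and so stays within the usual scatter. The added group brings a further six-membered aromatic ring of carbon only, yet this step is not resolved from zero, whereas the two replacements of the methyl group itself, a 4.2-fold higher number from compound 1 to compound 2 (0.63 log units; beyond the scatter) and a 2.3-fold higher number from compound 1 to compound 3 (0.37 log units; beyond the scatter), both lie beyond the scatter. Thus, among the changes shown on this ring, only the one that keeps the methyl group and adds benzyloxy at this new position stays within the scatter, and no measurement here accounts for that result.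

A single substituent at this position leaves open whether the result is particular to benzyloxy or also holds for methoxy, a primary amine, a carboxylic acid or a longer chain such as phenethyloxy. It also leaves open whether benzyloxy would behave the same way alongside the trifluoromethyl of compound 2 or the trifluoromethoxy of compound 3.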